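Three sulfamate compounds at one concentration, a fourth awaiting

The source may hold more compounds than are shown below. What is called first, only, known or untested is meant among the compounds shown, and "the series" means these compounds.

Compound 1 `CN(C)CCN(CCN(C)C)c1cccc(C(=O)N2CCc3ccc(OS(N)(=O)=O)cc3C2)c1`: 0%
Compound 2 `CCN(Cc1ccccc1)Cc1ccc(CN2CCc3ccc(OS(N)(=O)=O)cc3C2)cc1`: 1%
Compound 3 `CCCN(CCC)c1cccc(C(=O)N2CCc3ccc(OS(N)(=O)=O)cc3C2)c1`: 8.3%

The three compounds share a core and were read in an assay on HEK293 cells for inhibition of Steryl-sulfatase (Homo sapiens), tested at 0.1 uM; a lower number here means a weaker effect, a higher number a stronger effect of the compound at the concentration tested. The values of compound 1, compound 2 and compound 3 all lie within the usual scatter of one another, so compound 3 stands level with the other two rather than apart from them. Among the compounds with values here, the single step that can be followed, a number 8.3 percentage points higher from compound 1 to compound 3 (within the scatter), changes only the amine attached to the aromatic carbon and stays within the scatter.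

Compound 4 `CCN(Cc1ccc(Br)cc1)c1cccc(C(=O)N2CCc3ccc(OS(N)(=O)=O)cc3C2)c1` differs from compound 3 at that same aromatic carbon: (4-bromobenzyl)(ethyl)amino in place of dipropylamino on an aromatic carbon. Within the data shown here, the one measured step that bears on this place, a number 8.3 percentage points higher from compound 1 to compound 3 (within the scatter), was itself within the scatter, and compound 2, with its different linkage, shows a number no further from compound 3 than that. Nothing in the three numbers points to a step beyond the scatter in either direction in this assay, so the expected step is a number 2.3 percentage points lower from compound 3 to compound 4 (within the scatter), which is no more than the scatter.

Compound 4 is therefore estimated at 6%, between -6% and 22%.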

Compound 4, a percentage reported as inhibition, at one concentration (the size of the read-out at that concentration, not a potency): 24.2%
The estimate for compound 4 lay 18.2 percentage points below the measured number, and the stated range ends below it.
By their numbers in this assay, from the lowest: compounds 1, 2 and 3 (each within the scatter of the next); then compound 4.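

In this assay, the change at this aromatic carbon, meta to a large group, from dipropylamino to (4-bromobenzyl)(ethyl)amino gives a number 15.9 percentage points higher from compound 3 to compound 4 (beyond the scatter), whereas the earlier step at the same place, a number 8.3 percentage points higher from compound 1 to compound 3 (within the scatter), did not leave the scatter. Measured against bis(2-(dimethylamino)ethyl)amino, the same entering group gives a number 24.2 percentage points higher from compound 1 to compound 4 (beyond the scatter), so the amine at this position can shift the read-out, and among these amines the one carrying a six-membered aromatic ring of carbon only and a bromine is the one that does so. No measurement shown here accounts for this rise, so the reason for it stays unknown.

Going by these compounds, the entering group differs from dipropylamino in its ring, its bromine and its ethyl chain all at once, so it remains open whether a plain benzyl group, a 4-chlorobenzyl group or a longer chain in place of the ethyl would give a similar step. The read-out is also a single-concentration percentage, which leaves the potency of compound 4 open, along with whether its gain would hold at other concentrations.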